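The source may hold more compounds than are shown below. What is called first, only, known or untested is meant among the compounds shown, and "the series" means these compounds.

Measured compounds in an assay on HL-60 cells for agonist activity at vitamin D3 receptor (Homo sapiens), read by microscopy, with a stated time of 96 h; on this read-out higher numbers stand for an effect only at larger amounts of compound and lower numbers for an effect already at smaller amounts:
compound 1, `CCn1c(C(=O)NCCN)ccc1C(CC)(CC)c1ccc(OCC(=O)C(C)(C)C)c(C)c1`, gives 120 nM
compound 2, `CCn1c(C(=O)N(C)c2ccccc2)ccc1C(CC)(CC)c1ccc(OCC(=O)C(C)(C)C)c(C)c1`, gives 18500 nM
compound 3, `CCOC(=O)CC(C)OC(=O)c1ccc(C(CC)(CC)c2ccc(OCC(=O)C(C)(C)C)c(C)c2)n1CC`, gives > 50000 nM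

For compound 3 the result is a limit of the assay and not a number, so it sits at the limit of > 50000 nM in this assay, at which 1 of the 3 values shown sits. Compound 3 therefore stands at the weak end of the three measured compounds, with an at least 410-fold higher number from compound 1 to compound 3 (2.61 log units; beyond the scatter) and an at least 2.7-fold higher number from compound 2 to compound 3 (0.43 log units; beyond the scatter), both beyond the scatter.

Compound 4, `CCn1c(C(=O)Nc2cccc(C(F)(F)F)c2)ccc1C(CC)(CC)c1ccc(OCC(=O)C(C)(C)C)c(C)c1`, differs from compound 3 by a group of 11 heavy atoms (7 carbon, 1 nitrogen, 3 fluorine; one six-membered aromatic ring of carbon only) in place of a group of 9 heavy atoms (6 carbon, 3 oxygen; no ring), on a carbonyl carbon. For the measured compounds named here, two measured steps bear on this change. The step of an at least 2.7-fold higher number from compound 2 to compound 3 (0.43 log units; beyond the scatter) ran from an amide bearing an aromatic ring on the nitrogen to the ester chain, and compound 4 reverses that direction, returning to an amide with an aromatic ring, now with an amide hydrogen and a trifluoromethyl group. The step of an at least 410-fold higher number from compound 1 to compound 3 (2.61 log units; beyond the scatter) shows the widest gap among the amides measured. On this basis a downward step is expected, an at least 8.3-fold lower number from compound 3 to compound 4 (0.92 log units; beyond the scatter), most likely landing nearer compound 2 than compound 1. Compound 4 is estimated at 6000 nM in this assay, within a range from 800 nM to 50000 nM.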

Compound 4, half-maximal effective concentration: > 50000 nM
Compound 4: a limit, no number (the forecaster's own chance of this, stated with the estimate: 25%); at least 8.3-fold (0.92 log units) between middle value and limit.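

In this assay compound 4 also ends at a limit and not a number, so the step between compound 3 and compound 4 cannot be read: the limit of > 50000 nM in this assay, at which 2 of the 4 values shown sit. The amide hydrogen on this carbonyl carbon is not enough in itself: compound 4 carries one, as compound 1 does, yet 3-(trifluoromethyl)phenyl in place of 2-aminoethyl on the amide-type nitrogen gives a large step (an at least 410-fold higher number from compound 1 to compound 4 (2.61 log units; beyond the scatter)). Going from the methyl(phenyl)amino of compound 2 to the (3-(trifluoromethyl)phenyl)amino of compound 4 does not lower the number either (an at least 2.7-fold higher number from compound 2 to compound 4 (0.43 log units; beyond the scatter)), which leaves compound 1, with its 2-aminoethyl, the only one of the four with an effect at small amounts.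

The compounds shown leave open whether the result of compound 1 rests on the amine of its 2-aminoethyl or on the lack of an aromatic ring on that nitrogen, which a 2-hydroxyethyl group or a longer 3-aminopropyl chain there could separate. An unsubstituted phenylamino group would show how the step from compound 2 divides between the amide hydrogen and the trifluoromethyl.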